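Fluorine on the Anilide Ring of a Nitrobenzoxadiazole Glutathione Ester

This account rests on a few compounds, and the source may have more. Where it says the series, first, only, none or still open, it means among the compounds named here.

Compound 1 `O=C(O)CCC(=O)OCCCCCCSc1ccc([N+](=O)[O-])c2nonc12` gives 160 nM in an assay on isolated protein for inhibition of glutathione S-transferase Mu 2 (Homo sapiens), with a stated time of 10 min; a lower number here means a stronger inhibitor, a higher number a weaker inhibitor.
Compound 2 `O=C(CCC(=O)OCCCCCCSc1ccc([N+](=O)[O-])c2nonc12)Nc1ccccc1` gives 700 nM in this assay.

Of the two measured compounds, compound 2 has the higher number: the step of a 4.4-fold higher number from compound 1 to compound 2 (0.64 log units; beyond the scatter) lies beyond the scatter, so compound 2 is the weaker inhibitor of the pair. Compound 3 `O=C(CCC(=O)OCCCCCCSc1ccc([N+](=O)[O-])c2nonc12)Nc1ccccc1F` keeps everything of compound 2 except (fluoro in place of hydrogen on an aromatic carbon). Going by the values given here, the only measured step, a 4.4-fold higher number from compound 1 to compound 2 (0.64 log units; beyond the scatter), concerns the carbonyl carbon and not the aromatic ring of the anilino group, so no measured step bears directly on the change to compound 3. Among the compounds with values here, with no comparable step in hand, the expected step of no change at the digits printed from compound 2 to compound 3 (within the scatter) is taken to fall within the scatter. For compound 3 the estimated value in this assay is therefore 700 nM, with a range from 300 nM to 1700 nM.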

Compound 3, half-maximal inhibitory concentration: 350 nM
Estimate against measurement, compound 3: 2.0-fold (0.30 log units) above, and the stated range covers the measured number.
By their numbers in this assay, from the lowest: compound 1; then compounds 3 and 2 (each within the scatter of the next).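

In this assay fluoro in place of hydrogen on the anilide ring, ortho to a large group, gives a 2.0-fold lower number from compound 2 to compound 3 (0.30 log units; within the scatter) and so leaves the (2-fluorophenyl)amino amide indistinguishable from the parent anilide at this position. The acid remains the stronger inhibitor, with a 2.2-fold higher number from compound 1 to compound 3 (0.34 log units; beyond the scatter) still beyond the scatter, so this fluoro does not remove the separation between the free acid and the amide. Nothing available here explains these numbers.

As far as these compounds go, whether a chlorine, a methoxy group or a trifluoromethyl group on this same ring carbon would match fluoro remains open. So does whether a second fluorine on the ring, or a simple alkyl amine in place of the anilino group, would move the number beyond the scatter.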